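The source may hold more compounds than are shown below. What is called first, only, known or untested is meant among the compounds shown, and "the series" means these compounds.

Measured so far:
compound 1 `COc1ccc(N(C)c2nc(C)nc3ccccc23)cc1C(=O)NCC[Se]C#N`, 1170 nM
compound 2 `C[Se]c1ccc(N(C)c2nc(C3CC3)nc3ccccc23)cc1`, 21 nM
compound 3 `C[Se]c1ccc(N(C)c2nc(C)nc3ccccc23)cc1C`, 8 nM

In a functional assay on RKO cells (Homo sapiens) for inhibition, read by MTT assay, with a stated time of 48 h (a higher number here means a weaker inhibitor, a lower number a stronger inhibitor), compound 1 stands at the highest of the three numbers. Its nearest neighbour is compound 2, whose number lies below it by a margin beyond the scatter, and its furthest is compound 3, whose number lies lower still, again beyond the scatter. Compound 1 is thus the weakest inhibitor of the three on these numbers.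

The next compound to be measured is compound 4 `COc1ccc(N(C)c2nc(C)nc3ccccc23)cc1OCCCCCC[Se]C#N`, which differs from compound 1 in one place: a group of 10 heavy atoms (7 carbon, 1 nitrogen, 1 oxygen, 1 selenium; no ring) in place of a group of 8 heavy atoms (4 carbon, 2 nitrogen, 1 oxygen, 1 selenium; no ring), on an aromatic carbon. Among the compounds with values here, no pair of measured compounds separated by a single change is available, so there is no measured step to lean on; the expectation rests on the numbers of compounds 1, 2 and 3 alone. A moderate move toward a lower number in this assay is expected, beyond the scatter but leaving compound 4 well above compounds 2 and 3. The expected step in this assay is a 3.3-fold lower number from compound 1 to compound 4 (0.52 log units; beyond the scatter). Compound 4 is expected to give about 350 nM, within a range of 60 nM to 2000 nM.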

Compound 4, half-maximal inhibitory concentration: 1540 nM
The estimate for compound 4 lay 4.4-fold (0.64 log units) below the measured number, within the range that was stated.
By their numbers in this assay, from the lowest: compound 3; then compound 2; then compounds 1 and 4 (each within the scatter of the next).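

In this assay, exchanging the group on this aromatic carbon, ortho to a methoxy group, gives a 1.3-fold higher number from compound 1 to compound 4 (0.12 log units; within the scatter) and so stays within the scatter. Within the data shown here, at this position, then, the group of 8 heavy atoms, with 1 double bond and 1 hydrogen-bond donor, and the group of 10 heavy atoms, with 0 hydrogen-bond donors, give numbers that this read-out does not separate, something the earlier compounds, none a single change apart, could not show. No measurement at hand bears on why this is so.

The compounds shown leave open whether a shorter or longer chain at this aromatic carbon would give a number beyond the scatter of these two. They also leave open what an amine or a carboxylic acid there would give.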